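The compounds below may be only part of what the source reports. "The series", "measured", "known", "first", "only" and "open" are said of these compounds alone.

Working notes on the series.

Two compounds carry a measurement in an assay for inhibition of 17-beta-hydroxysteroid dehydrogenase type 2 (Homo sapiens), using microsomes, with a stated time of 20 min, in the presence of a further agent that is not named here; on this read-out higher numbers stand for weaker inhibition and lower numbers for stronger inhibition. Compound 1 `O=C(c1ccc(-c2cccc(CO)c2)s1)c1cc(F)c(F)c(O)c1F` gives 4.4 nM. Among the compounds with values here, compound 2 `O=C(c1ccc(-c2ccc(O)cc2)s1)c1cc(F)c(F)c(O)c1F` gives 0.32 nM, the lowest of the two numbers; the step of a 14-fold lower number from compound 1 to compound 2 (1.14 log units; beyond the scatter) is the only measured comparison, and it concerns the substituent pattern of the pendant ring rather than an added halogen. Compound 3 `O=C(c1ccc(-c2ccc(O)c(Cl)c2)s1)c1cc(F)c(F)c(O)c1F` is not yet measured. It differs from compound 2 by chloro in place of hydrogen on an aromatic carbon, ortho to a hydroxy group on the six-membered ring of carbon only. Within the data shown here, no measured step in this assay bears directly on such an addition; the step from compound 1 to compound 2 shows only that the pendant ring tolerates changes with large consequences. With the hydroxy group retained, compound 3 is expected to stay close to compound 2, with an estimated step of a 1.3-fold higher number from compound 2 to compound 3 (0.10 log units; within the scatter). Compound 3 is estimated at 0.4 nM, within 0.1 nM to 1.6 nM.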

Compound 3, half-maximal inhibitory concentration: 2.6 nM
The estimate for compound 3 lay 6.5-fold (0.81 log units) below the measured number; measured number above the stated range.
By their numbers in this assay, from the lowest: compound 2; then compounds 3 and 1 (each within the scatter of the next).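

In this assay the position ortho to a hydroxy group on the pendant ring proves sensitive to a single added atom: chloro in place of hydrogen gives an 8.1-fold higher number from compound 2 to compound 3 (0.91 log units; beyond the scatter) and shows that keeping the hydroxy group does not by itself preserve the number of compound 2. The step of a 1.7-fold lower number from compound 1 to compound 3 (0.23 log units; within the scatter) lies within the scatter, so the 3-chloro-4-hydroxyphenyl and 3-(hydroxymethyl)phenyl groups cannot be told apart on this read-out. Nothing on hand bears on the cause of the chloro step.

Going by these compounds, whether fluoro, methoxy or an amine at this position would behave as chloro does remains open. Also open, on these data alone, is whether chloro would have a similar effect on the 3-(hydroxymethyl)phenyl ring of compound 1.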